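The compounds below may be only part of what the source reports. "The series", "measured", "known", "first", "only" and "open" are said of these compounds alone.

Among the measured compounds shown here, in a physicochemical assay for lipophilicity, read by HPLC, at pH 7.5 (on this read-out higher numbers stand for higher lipophilicity and lower numbers for lower lipophilicity), compound 1 `CC[C@@H](Nc1c(C#N)c(-c2ccc(-c3cccc(C)c3)cc2)nc2cnccc12)C(N)=O` gives 3, while compound 2 `CC[C@@H](Nc1c(C#N)c(-c2ccc(-c3ccncc3C)cc2)nc2cnccc12)C(N)=O` gives 2, the lower of the two numbers so far. Compound 3 `CC[C@@H](Nc1c(C#N)c(-c2ccc(-c3cccc(Cl)c3OC)cc2)nc2cnccc12)C(N)=O` has not yet been measured. The structural change from compound 2 is this: 3-chloro-2-methoxyphenyl in place of 3-methylpyridin-4-yl on an aromatic carbon. In words, 3-chloro-2-methoxyphenyl stands in place of 3-methylpyridin-4-yl on an aromatic carbon. For the measured compounds named here, only one measured step bears on it: a number 1.00 log units lower from compound 1 to compound 2 (beyond the scatter), with 3-methylpyridin-4-yl in place of 3-methylphenyl. The new change runs the opposite way, returning to a six-membered aromatic ring of carbon only, as in compound 1 at 3. Going by the values given here, no measured compound carries the 3-chloro-2-methoxyphenyl group, so the range stays wide. A rise of similar size, beyond the scatter, is expected, estimated as a number 1.20 log units higher from compound 2 to compound 3 (beyond the scatter). Compound 3 is estimated at 3.2, with an expected range from 2.6 to 3.8.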

Compound 3, distribution coefficient: 3.1
Estimate against measurement, compound 3: 0.10 log units above; low and high end bracket the measured number.
By their numbers in this assay, from the lowest: compound 2; then compounds 1 and 3 (each within the scatter of the next).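

In this assay, putting 3-chloro-2-methoxyphenyl in place of 3-methylpyridin-4-yl gives a number 1.10 log units higher from compound 2 to compound 3 (beyond the scatter), so this position allows the number to go up again after a number 1.00 log units lower from compound 1 to compound 2 (beyond the scatter). Putting 3-chloro-2-methoxyphenyl in place of 3-methylphenyl gives a number 0.10 log units higher from compound 1 to compound 3 (within the scatter), which means that two differently substituted rings of carbon only read alike here, and among these three compounds only compound 2, whose ring holds a nitrogen, stands apart. Nothing available explains why the numbers fall this way.

The compounds shown leave open how a ring carrying only the chlorine or only the methoxy group would read, as compound 3 carries both together. Also open, going by these compounds, is where the number would fall with an amine or a carboxylic acid on this ring.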